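This account rests on a few compounds, and the source may have more. Where it says the series, first, only, none or still open, it means among the compounds named here.

Three compounds of the shared core carry the same substituent on the saturated ring carbon of the five-membered ring and differ only in that group. In a functional assay on the whole organism (strain albino) for inhibition, with Rattus norvegicus as the target, read by paw edema, with stated times of 1 h and 2 h, at a dose of 200 mg/kg by the oral route (on this read-out higher numbers stand for more inhibition at the one dose given (going by the name of the read-out) and lower numbers for less inhibition), compound 1 `COc1ccc([C@H]2CC(c3cc4ccccc4oc3=O)=NN2c2ccccc2)cc1` gives 24.8%, compound 2 `O=c1oc2ccccc2cc1C1=NN(c2ccccc2)[C@@H](/C=C/c2ccccc2)C1` gives 26.7%, and compound 3 `O=c1oc2ccccc2cc1C1=NN(c2ccccc2)[C@@H](c2ccc(Cl)cc2Cl)C1` gives 56.7%. Compound 2 stands second highest of the three; its nearest neighbour is compound 1, with a number 1.9 percentage points higher from compound 1 to compound 2 (within the scatter), and its furthest is compound 3, with a number 30 percentage points higher from compound 2 to compound 3 (beyond the scatter). The step of a number 31.9 percentage points higher from compound 1 to compound 3 (beyond the scatter) is the other large one in the set.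

Compound 4 `CN(C)c1ccc([C@H]2CC(c3cc4ccccc4oc3=O)=NN2c2ccccc2)cc1` is not yet measured in this assay. Relative to compound 2 the change is 4-(dimethylamino)phenyl in place of 2-phenylethenyl on a saturated ring carbon. Among the measured compounds shown here, no measured step involves this group. The two steps that bear on it are the exchange of a para-substituted phenyl for 2-phenylethenyl, which stayed within the scatter from compound 1 to compound 2, and the exchange for 2,4-dichlorophenyl, which gave the large rise to compound 3. A para-substituted phenyl re-enters here, so the step of a number 0.3 percentage points higher from compound 2 to compound 4 (within the scatter) is expected to stay within the scatter. Compound 4 is estimated at 27%, in the range 14% to 42%.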

Compound 4, a percentage reported as inhibition, in the whole organism at one dose (the size of the read-out at that dose, not a potency): 28.4%
Compound 4: the middle estimate sits 1.4 percentage points below what was measured, within the range that was stated.
By their numbers in this assay, from the lowest: compounds 1, 2 and 4 (each within the scatter of the next); then compound 3.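

In this assay, dimethylamino in place of methoxy on an aromatic carbon gives a number 3.6 percentage points higher from compound 1 to compound 4 (within the scatter), and 4-(dimethylamino)phenyl in place of 2-phenylethenyl on the saturated ring carbon gives a number 1.7 percentage points higher from compound 2 to compound 4 (within the scatter), so compound 4 joins compound 1 and compound 2 in one group within the scatter. Against 2,4-dichlorophenyl the same group gives a number 28.3 percentage points lower from compound 3 to compound 4 (beyond the scatter), so the nitrogen-bearing phenyl does not bring compound 4 close to compound 3, which remains the only compound apart from the others at this position. No measured evidence accounts for this separation.

As far as these compounds go, it remains open whether the number in compound 3 depends on having two chloro groups or would persist with a single chloro group on the phenyl. A carboxylic acid or a hydroxy group on that phenyl could show whether any other group leaves the lower cluster.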